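This account rests on a few compounds, and the source may have more. Where it says the series, first, only, none or still open, it means among the compounds named here.

Of the compounds shown here, three that share one core have been tested in a functional assay on HeLa cells (Homo sapiens) for cytotoxicity, read by WST assay, with a stated time of 48 h; on this read-out higher numbers stand for weaker inhibition and lower numbers for stronger inhibition. Compound 1 `COc1ccc(/C=C/C[C@H]2C[C@@H]([C@@H](O)c3ccccc3)CO[C@@H]2c2ccccc2)cc1` gives 8300 nM in this assay. Compound 3 `COc1ccc(/C=C/C[C@@H]2C[C@@H]([C@@H](O)c3ccc(OC)c(OC)c3)CO[C@H]2c2ccccc2)cc1OC` gives 16100 nM, and compound 2 `COc1ccc(CCC[C@@H]2C[C@@H]([C@@H](O)c3ccc(OC)c(OC)c3)CO[C@H]2c2ccc(OC)c(OC)c2)cc1OC` gives 35700 nM. Among these three numbers compound 1 sits at the low end: compound 3 lies within the usual scatter of it, so the two cannot be told apart, while compound 2 lies beyond the scatter with the higher number.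

The next compound, compound 4 `Oc1ccc(/C=C/C[C@H]2C[C@@H]([C@@H](O)c3ccccc3)CO[C@@H]2c2ccccc2)cc1`, is built from compound 1 by a single change: hydrogen in place of methyl on an oxygen on an aromatic ring. Going by the values given here, no pair of measured compounds differs in exactly this way, so there is no measured step to lean on. Such a small change, the loss of one carbon with no ring and no change in donors or acceptors as counted, gives no reason from the numbers at hand to expect a shift beyond the scatter in either direction. The step from compound 1 to compound 4 is therefore expected to be about a 1.0-fold lower number from compound 1 to compound 4 (0.02 log units; within the scatter). Compound 4 is estimated to give 8000 nM in this assay, with a likely range from 3000 nM to 22000 nM.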

Compound 4, half-maximal inhibitory concentration: 14400 nM
Beside the measured number, compound 4's estimate is 1.8-fold (0.26 log units) below it; the range from low to high includes it.
By their numbers in this assay, from the lowest: compounds 1, 4 and 3 (each within the scatter of the next); then compound 2.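

In this assay, the swap of methoxy for hydroxy on the 4-methoxyphenyl group gives a 1.7-fold higher number from compound 1 to compound 4 (0.24 log units; within the scatter) and so compound 4 cannot be told apart from compound 1 on this read-out. This is the first pair shown that differs in one place only, which makes it the first direct look at this position; the three earlier compounds differ from one another in several places at once and could not isolate this group. On this background, the methyl on that oxygen can therefore be lost without a change that rises above the usual scatter, and no measurement at hand bears on why the two numbers lie so close.

As far as these compounds go, this is a single step on a single background, so it remains open whether the same swap would read the same way on compound 2 or compound 3, which carry further methoxy groups on their aromatic rings. Also open, from the compounds shown here alone, is what a longer ethoxy group, an amine or a carboxylic acid at this same place on the ring would give.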